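A new group at the assay's limit

The compounds below may be only part of what the source reports. "The series", "measured", "known", "first", "only" and "open" are said of these compounds alone.

In an ADME assay on HepG2 cells (Homo sapiens) for cytotoxicity, read by CellTiter-Glo and resazurin assay, with a stated time of 72 h (a lower number here means that less compound is needed, a higher number that more compound is needed for the effect), compound 1 (`CCOC(=O)CCCCCOc1cccc(CN(C(=O)c2ccc(-c3cccc(N(C)C)c3)cc2)C(C)C)c1`) gives > 26000 nM as a limit of the assay and not a number. Compound 2 (`CCOC(=O)CCCCCOc1cccc(CN(C(=O)c2ccc(-c3ccc4ccccc4c3)cc2)C(C)C)c1`) gives > 26000 nM and this is also a limit. Compound 3 (`CCOC(=O)CCCCCOc1cccc(CN(C(=O)c2ccc(-c3cccc(OCC(C)C)c3)cc2)C(C)C)c1`) gives > 26000 nM and this too is a limit. That leaves compound 3 at the limit of > 26000 nM in this assay, at which 3 of the 3 values shown sit, with no exact number known.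

Compound 4 (`CCOC(=O)CCCCCOc1cccc(CN(C(=O)c2ccc(-c3ccc(C(C)=O)s3)cc2)C(C)C)c1`) carries 5-acetylthiophen-2-yl in place of 3-(isobutoxy)phenyl on an aromatic carbon. Two measured swaps of the same group bear on this change, a step that the two limits leave unreadable from compound 1 to compound 2 and a step that the two limits leave unreadable from compound 2 to compound 3 and neither has a size that can be read. They point in no direction, so no move beyond the scatter is expected in this assay for this new group. The estimated change is a step that the limit leaves unreadable from compound 3 to compound 4 and it remains only an expectation. Compound 4 is estimated at 30000 nM with an expected range from 16000 nM to 60000 nM and a report as a limit is the likeliest outcome.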

Compound 4, half-maximal effective concentration: > 26000 nM
Compound 4 was reported as a limit; the forecaster's own chance of this, stated with the estimate: 85%; the middle value does not contradict the limit.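

In this assay compound 4 gives > 26000 nM as a limit of the assay and not a number. Within the data shown here, no step from compound 1, compound 2 or compound 3 to compound 4 can be read. The compounds shown leave open at what concentration any of them would reach the half-maximal effect.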